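Bromo to trifluoromethyl on a pyrazoline-thiazole scaffold

This account rests on a few compounds, and the source may have more. Where it says the series, first, only, none or still open, it means among the compounds named here.

Of the compounds shown here, two have been measured in a functional assay on MCF7 cells (Homo sapiens) for antiproliferative activity, read by MTT assay, with a stated time of 48 h; a higher number here means a weaker inhibitor, a lower number a stronger inhibitor. Compound 1 `COc1ccc(C2=NN(c3nc(-c4ccc(C(F)(F)F)cc4)cs3)C(c3cccs3)C2)cc1` gives 45700 nM in this assay. Compound 2 `Cc1ccc(C2=NN(c3nc(-c4ccc(Br)cc4)cs3)C(c3cccs3)C2)cc1` gives 2010 nM in this assay, the lower of the two numbers and well beyond the scatter from compound 1. Compound 3 `Cc1ccc(C2=NN(c3nc(-c4ccc(C(F)(F)F)cc4)cs3)C(c3cccs3)C2)cc1` has not yet been measured. It differs from compound 2 in one place: trifluoromethyl in place of bromo on an aromatic carbon. Compound 3 carries the same trifluoromethyl group that sits on compound 1, and compound 1 gives the weaker result of the pair, so the step from compound 2 to compound 3 is expected to lead upward, to a weaker inhibitor, though the two measured compounds also differ elsewhere and the outcome is uncertain. The estimated step is a 4.0-fold higher number from compound 2 to compound 3 (0.60 log units; beyond the scatter). For compound 3 the expected value in this assay is 8000 nM, with a range from 2000 nM to 40000 nM.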

Compound 3, half-maximal inhibitory concentration: 31500 nM
Compound 3: middle estimate off by 3.9-fold (0.60 log units), on the low side, within the range that was stated.
By their numbers in this assay, from the lowest: compound 2; then compounds 3 and 1 (each within the scatter of the next).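

In this assay, trifluoromethyl in place of bromo, with the rest of the molecule unchanged, gives a 16-fold higher number from compound 2 to compound 3 (1.20 log units; beyond the scatter) and so shows that this single change at this ring position is enough to cost a large amount of activity. Methyl in place of methoxy, at the other changed place, gives a 1.5-fold lower number from compound 1 to compound 3 (0.16 log units; within the scatter) and so makes no clear difference while trifluoromethyl is present, which means the wide gap between compound 2 and compound 1 no longer needs that second difference to account for it. Nothing available explains why trifluoromethyl does so much worse than bromo here.

From the compounds shown here alone, whether chloro, an amine or a carboxylic acid at this position would match bromo remains open. Also open, going by these compounds, is whether bromo keeps its advantage with methoxy in place of methyl.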